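A few compounds are considered here, and "the series" means these few. Any claim that something is new, unique, unknown or untested is made for them only; others in the source may bear on it.

Working notes on the series built on the shared core of compound 1 `O=C(O)c1ccc(-c2nn(Cc3ccccc3)c3ccccc23)cc1`, as read in a functional assay on cells (Platelet, Homo sapiens) for inhibition; on this read-out higher numbers stand for weaker inhibition and lower numbers for stronger inhibition. Compound 1 gives > 10000 nM, which is a limit and not a number. Within the data shown here, compound 2 `COC(=O)c1ccc(-c2nn(Cc3ccccc3)c3ccccc23)cc1` gives 560 nM, the one true number so far. Compound 3 `CC(C)OC(=O)c1ccc(-c2nn(Cc3ccccc3)c3ccccc23)cc1` gives > 10000 nM, again a limit. Its place on the scale is the limit of > 10000 nM in this assay, at which 2 of the 3 values shown sit.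

The next step leads to compound 4 `NC(=O)c1ccc(-c2nn(Cc3ccccc3)c3ccccc23)cc1`: amino in place of isopropoxy on a carbonyl carbon. Three measured steps change the group at this same carbonyl: an at least 17-fold lower number from compound 1 to compound 2 (1.25 log units; beyond the scatter), then an at least 17-fold higher number from compound 2 to compound 3 (1.25 log units; beyond the scatter), and finally a step that the two limits leave unreadable from compound 1 to compound 3. The two readable steps are both large, so this site can move the read-out strongly, but they run in opposite directions and none of the three involves amino. Only compound 2 escapes the limit, and compound 1 and compound 3 both stay at it. A modest shift towards a lower number is therefore expected, with a real chance that no number can be read at all. The expected step is an at least 1.6-fold lower number from compound 3 to compound 4 (0.22 log units; that floor lies within the scatter). The estimate for compound 4 is 6000 nM, with an expected range from 1000 nM to 25000 nM.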

Compound 4, half-maximal inhibitory concentration: > 10000 nM
Compound 4: no number, only a limit (the forecaster's own chance of this, stated with the estimate: 55%); middle value at least 1.6-fold (0.22 log units) from the limit.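

In this assay compound 4 gives > 10000 nM, which is a limit and not a number. Amino on this carbonyl carbon therefore does not keep the readable value seen with methoxy, giving an at least 17-fold higher number from compound 2 to compound 4 (1.25 log units; beyond the scatter), while the steps from compound 1 and from compound 3 to compound 4 cannot be read, as each joins two limits. With a fourth group now on this carbonyl carbon, methoxy in compound 2 remains the only one that yields a number, and hydroxy in compound 1, isopropoxy in compound 3 and amino in compound 4 all stay at the limit, so the series reads as one exception to a common ceiling rather than as a graded trend: the limit of > 10000 nM in this assay, at which 3 of the 4 values shown sit.

The true values of compound 1, compound 3 and compound 4 remain unknown, so no order among these three can be stated and the size of any difference among them stays open. Also open, going by these compounds, is whether ethoxy or methylamino on the same carbonyl carbon would give a readable number, which would show whether the value of compound 2 is confined to methoxy alone.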